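Removing the cyano from compound 3

This account rests on a few compounds, and the source may have more. Where it says the series, first, only, none or still open, it means among the compounds named here.

Compound 3 `Cc1cc(Cl)nc2c1c(C#N)cn2-c1ccc(C(C)C)cc1Br` gives 446 nM in an assay on isolated protein for binding affinity to corticotropin-releasing factor receptor 1 (Rattus norvegicus) (on this read-out higher numbers stand for weaker inhibition and lower numbers for stronger inhibition), the highest of the two numbers recorded in the series; its nearest neighbour is compound 1 `Cc1cc(C)c2ccn(-c3ccc(C(C)C)cc3Br)c2n1`, which gives 47 nM, a lower number beyond the scatter. Compound 2 `Cc1ccnc2c1ccn2-c1ccc(C(C)C)cc1Br` reaches only the limit > 10000 nM in this assay. Going by the values given here, the single measured step, an at least 210-fold higher number from compound 1 to compound 2 (2.32 log units; beyond the scatter), is therefore a lower bound on its true size, because of the limit of > 10000 nM in this assay, at which 1 of the 3 values shown sits.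

Compound 4 `Cc1cc(Cl)nc2c1ccn2-c1ccc(C(C)C)cc1Br` differs from compound 3 by hydrogen in place of cyano on an aromatic carbon. The measured step removes a methyl from an aromatic carbon of the core, not a cyano, so it gives no direct guide; it shows only that removal of a small group from the shared core can cost heavily. Among the compounds with values here, compound 1, which also carries no cyano, sits well below compound 3 in this assay, though the two differ in another group as well and no step between them is recorded. On balance a moderate gain is expected for compound 4, a 3.0-fold lower number from compound 3 to compound 4 (0.47 log units; beyond the scatter), with wide uncertainty. The estimate for compound 4 in this assay is 150 nM, expected to fall between 40 nM and 600 nM.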

Compound 4, inhibition constant: 79 nM
For compound 4 the middle estimate is 1.9-fold (0.28 log units) above the measured one; low and high end bracket the measured number.
By their numbers in this assay, from the lowest: compounds 1 and 4 (each within the scatter of the next); then compound 3. At a limit, above all of these: compound 2.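

In this assay, the cyano on the aromatic carbon of the five-membered aromatic ring proves dispensable in the chloro series, and hydrogen serves better there: a 5.6-fold lower number from compound 3 to compound 4 (0.75 log units; beyond the scatter). On the other aromatic carbon, where the earlier step showed only that losing a methyl is costly, chloro in place of methyl gives a 1.7-fold higher number from compound 1 to compound 4 (0.23 log units; within the scatter), so this assay does not separate the two groups at that carbon. Chloro in place of hydrogen on that carbon gives an at least 120-fold lower number from compound 2 to compound 4 (2.10 log units; beyond the scatter), which shows that chloro restores what the loss of methyl took away, though the size of this step is only a lower bound set by the limit of compound 2: the limit of > 10000 nM in this assay, at which 1 of the 4 values shown sits.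

The compounds shown leave open whether another group on that carbon, such as an amine, a methoxy or a longer chain, would hold the number as chloro and methyl do, and whether a group other than cyano on the five-membered aromatic ring, such as a carboxylic acid or an amide, would be tolerated. They also leave open whether the step on removing the cyano has the same size when methyl stands in place of chloro.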